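From (3-(trifluoromethyl)phenyl)carbonyl to 2-cyanophenyl: compound 4

The source may hold more compounds than are shown below. What is called first, only, known or untested is meant among the compounds shown, and "the series" means these compounds.

In a functional assay on U-251 cells (Homo sapiens) for antiproliferative activity, read by MTT assay, with a stated time of 24 h (a lower number here means a stronger inhibitor, a higher number a weaker inhibitor), compound 1 (`COc1cc(OC)c(-c2coc3cc(OCC(=O)c4cccc(C(F)(F)F)c4)ccc3c2=O)cc1OC`) gives > 10000 nM, which is a limit and not a number. Compound 1 thus stands at the limit of > 10000 nM in this assay, at which 2 of the 3 values shown sit. Compound 3 (`COc1cc(OC)c(-c2coc3cc(OCc4ccccc4C(F)(F)F)ccc3c2=O)cc1OC`) gives > 10000 nM, also a limit. Within the data shown here, compound 2 (`COc1cc(OC)c(-c2coc3cc(OCc4ccccc4C)ccc3c2=O)cc1OC`) gives 2000 nM, the only true number so far.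

Compound 4 (`COc1cc(OC)c(-c2coc3cc(OCc4ccccc4C#N)ccc3c2=O)cc1OC`) carries 2-cyanophenyl in place of (3-(trifluoromethyl)phenyl)carbonyl on a saturated chain carbon bound to an oxygen on an aromatic ring.

Two measured steps make the same kind of replacement. The first, an at least 5.0-fold lower number from compound 1 to compound 2 (0.69 log units; beyond the scatter), lies beyond the scatter. The second, a step that the two limits leave unreadable from compound 1 to compound 3, cannot be sized from its two limits. A third step, an at least 5.0-fold higher number from compound 2 to compound 3 (0.69 log units; beyond the scatter), shows that the group on the aromatic carbon decides the outcome, so leaving the carbonyl does not by itself secure a gain.

Compound 4 has neither the methyl of compound 2 nor the trifluoromethyl of compound 3, so it is expected to fall between those two outcomes, and it may well remain at the limit. In this assay the expected change is a modest move towards a lower number, an at least 1.6-fold lower number from compound 1 to compound 4 (0.22 log units; that floor lies within the scatter). For compound 4 the estimate is 6000 nM, with an expected range of 1800 nM to 20000 nM.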

Compound 4, half-maximal inhibitory concentration: 980 nM
Beside the measured number, compound 4's estimate is 6.1-fold (0.79 log units) above it; measured number below the stated range.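

In this assay, cyano on the aromatic carbon gives a 2.0-fold lower number from compound 2 to compound 4 (0.31 log units; beyond the scatter), so the methyl of compound 2 is not the only group there that reaches a true number, and compound 4 is now the strongest of the compounds shown. Cyano in place of trifluoromethyl gives an at least 10-fold lower number from compound 3 to compound 4 (1.00 log units; beyond the scatter), and the full replacement of (3-(trifluoromethyl)phenyl)carbonyl by 2-cyanophenyl gives an at least 10-fold lower number from compound 1 to compound 4 (1.00 log units; beyond the scatter); both sizes are floors, each set by a limit and not by a number. Among the three groups compared on that aromatic carbon, only trifluoromethyl stays without a true number, and compound 1 and compound 3 remain the two compounds at a limit: the limit of > 10000 nM in this assay, at which 2 of the 4 values shown sit.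

The compounds shown leave open how far this tolerance on the aromatic carbon extends, for instance to an amine or a carboxylic acid there. They also leave open whether a carbonyl on the saturated chain carbon is compatible with cyano on the aromatic ring, as every step from compound 1 changes the carbonyl and the ring substituent together.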